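This account rests on a few compounds, and the source may have more. Where it says the series, first, only, none or still open, it means among the compounds named here.

Compound 1 `c1ccc(-c2cn3ccnc3c(-c3ccc4ncn(C5CCCCC5)c4c3)n2)cc1` is measured in a functional assay on ACHN cells (Homo sapiens) for inhibition, read by sulforhodamine B assay, with a stated time of 48 h, tested at 10 uM (a lower number here means less inhibition, a higher number more inhibition at the concentration tested (going by the name of the read-out)), at 35.9%. Compound 2 `CC(=O)c1ccc(-c2cn3ccnc3c(-c3ccc4ncn(C5CCCCC5)c4c3)n2)cc1` differs by an acetyl in place of hydrogen on an aromatic carbon, and in this assay compound 2 gives 4.32%. Among the compounds with values here, the change is a number 31.6 percentage points lower from compound 1 to compound 2 (beyond the scatter), so compound 2 stands lowest of the two numbers known, with compound 1 as its nearest neighbour beyond the scatter.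

Compound 3 `Clc1ccc(-c2cn3ccnc3c(-c3ccc4ncn(C5CCCCC5)c4c3)n2)cc1` is not yet measured. Its difference from compound 2 is chloro in place of acetyl on an aromatic carbon. Within the data shown here, only one measured step bears on this: the large drop a number 31.6 percentage points lower from compound 1 to compound 2 (beyond the scatter) came with the arrival of the acetyl that now leaves. Among the measured compounds shown here, no measured pair shows what a chloro at this place does. Because the removal of acetyl reverses the change behind a number 31.6 percentage points lower from compound 1 to compound 2 (beyond the scatter), a rise is expected, though its size is uncertain. The estimated step is a number 22.7 percentage points higher from compound 2 to compound 3 (beyond the scatter). Compound 3 is expected to give 27%, within a range from 5% to 50%.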

Compound 3, a percentage reported as inhibition, at one concentration (the size of the read-out at that concentration, not a potency): 5.45%
For compound 3 the middle estimate is 21.6 percentage points above the measured one; the measured number falls inside the stated range.
By their numbers in this assay, from the lowest: compounds 2 and 3 (each within the scatter of the next); then compound 1.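

In this assay putting chloro in place of acetyl on this aromatic carbon, para to a large group, gives a number 1.1 percentage points higher from compound 2 to compound 3 (within the scatter) and so leaves the two groups indistinguishable here. Set against hydrogen at the same place, chloro gives a number 30.5 percentage points lower from compound 1 to compound 3 (beyond the scatter) and acetyl gives a number 31.6 percentage points lower from compound 1 to compound 2 (beyond the scatter), so the large loss is not peculiar to acetyl: among these three compounds, both groups go with it and only the unsubstituted phenyl of compound 1 stands apart. Nothing measured here accounts for this.

Whether any group at this place keeps the level of compound 1 remains open, since only two replacements of hydrogen are shown. A fluoro, a methyl, an amine or a carboxylic acid could each show whether the loss extends beyond chloro and acetyl.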